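Swapping the aryl ketone of a chalcone series

A few compounds are considered here, and "the series" means these few. Any claim that something is new, unique, unknown or untested is made for them only; others in the source may bear on it.

Among the compounds with values here, compound 1 `COc1cc(C(=O)/C=C/c2cc(-c3cc(OC)c(OC)c(OC)c3)n3nc(-c4ccccc4)cc3n2)cc(OC)c1OC` was examined in a functional assay on DU-145 cells (Homo sapiens) for antiproliferative activity, read by MTT assay, with a stated time of 24 h (a higher number here means a weaker inhibitor, a lower number a stronger inhibitor), where compound 1 gives 34900 nM, the highest of the three numbers measured so far. Compound 2 `COc1ccc(-c2cc(/C=C/C(=O)c3cc(OC)c(OC)c(OC)c3)nc3cc(-c4ccccc4)nn23)cc1OC` gives 8300 nM, and a 4.2-fold lower number from compound 1 to compound 2 (0.62 log units; beyond the scatter). Compound 3 `COc1ccc(C(=O)/C=C/c2cc(-c3ccc(OC)c(OC)c3)n3nc(-c4ccccc4)cc3n2)cc1` gives 14600 nM, and a 1.8-fold higher number from compound 2 to compound 3 (0.25 log units; within the scatter). Compound 4 `COc1cc(-c2cc(/C=C/C(=O)c3ccc(C)c(C)c3)nc3cc(-c4ccccc4)nn23)cc(OC)c1OC` has not yet been measured; it differs from compound 1 in one place: 3,4-dimethylphenyl in place of 3,4,5-trimethoxyphenyl on a carbonyl carbon. The measured step that bears most directly on this change is the one in which the same 3,4,5-trimethoxyphenyl on the carbonyl carbon was replaced, a 1.8-fold higher number from compound 2 to compound 3 (0.25 log units; within the scatter), which stayed within the scatter. The other step, a 4.2-fold lower number from compound 1 to compound 2 (0.62 log units; beyond the scatter), concerns a different part of the molecule and offers no guide here. On this basis compound 4 is expected to show a step of a 1.1-fold higher number from compound 1 to compound 4 (0.06 log units; within the scatter), not beyond the scatter. The estimate for compound 4 is therefore 40000 nM, with a range from 15000 nM to 110000 nM.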

Compound 4, half-maximal inhibitory concentration: 15400 nM
Beside the measured number, compound 4's estimate is 2.6-fold (0.41 log units) above it; the range from low to high includes it.
By their numbers in this assay, from the lowest: compounds 2, 3 and 4 (each within the scatter of the next); then compound 1.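

Replacing the 3,4,5-trimethoxyphenyl on the carbonyl carbon does register in this assay: a 2.3-fold lower number from compound 1 to compound 4 (0.36 log units; beyond the scatter), whereas the earlier change at this place, to 4-methoxyphenyl, gave a 1.8-fold higher number from compound 2 to compound 3 (0.25 log units; within the scatter). The position therefore responds to a change of aryl group at least on the core of compound 1, and 3,4-dimethylphenyl, with no hydrogen-bond acceptors, is tolerated in place of a group with three. Nothing available explains this step.

Going by these compounds, it remains open whether 3,4-dimethylphenyl would produce a similar step on the core of compound 2, and whether the step follows from losing the methoxy groups or gaining the methyl groups. On these data alone, how an aryl group carrying an amine or a carboxylic acid would read at this place also remains open.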